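The source may report more compounds than this note shows. Statements on the series, on what has been measured and on what is new or still open speak of the compounds shown alone.

Measured so far in a functional assay on MDBK cells (Bos taurus) for cytotoxicity; a lower number here means that less compound is tolerated, a higher number that more compound is tolerated:

- Compound 1 `CO/N=C(\C#N)C(=O)NCC1=NOC(C)(C)C1`: > 100 ug/mL
- Compound 2 `CO/N=C(/C#N)C(=O)NCC1=NOC(C(C)(C)C)C1`: > 100 ug/mL
- Compound 3 `CCO/N=C(\C#N)C(=O)NCC1=NOC(C(C)(C)C)C1`: > 100 ug/mL

Each of these three values is a limit of the assay and not a number. In this assay, compound 3 gives > 100 ug/mL, and this limit is all that is known about it. It stands level with the other two compounds: the limit of > 100 ug/mL in this assay, at which 3 of the 3 values shown sit. None of the three can therefore be ranked against the others.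

Compound 4 `CC(C)(C)C1CC(CNC(=O)/C(C#N)=N/OCc2ccccc2)=NO1` differs from compound 3 in one place: phenyl in place of methyl on a saturated chain carbon bound to an oxygen on an unsaturated carbon. This puts phenyl in place of methyl on a saturated chain carbon bound to an oxygen on an unsaturated carbon, so that ethoxy becomes benzyloxy.

For the measured compounds named here, no pair of measured compounds differs in just one place, and no measured step exists to show what such a change does. The expectation therefore rests on the limit of compound 3 and on the fact that all three measured compounds sit at that same limit. The expected change is a number no higher from compound 3 to compound 4 (the limit leaves the size open), meaning no shift beyond the usual scatter, or else a modest one toward less compound being tolerated. Compound 4 may well report only a limit again. For compound 4 the estimated value is 100 ug/mL, with an expected range of 45 ug/mL to 200 ug/mL.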

Compound 4, half-maximal cytotoxic concentration: 100 ug/mL
Compound 4: the middle estimate sits on the measured number at the digits printed, within the range that was stated.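

In this assay, replacing methyl with phenyl on the saturated chain carbon bound to an oxygen on an unsaturated carbon, which turns ethoxy into benzyloxy, gives a number no higher from compound 3 to compound 4 (the limit leaves the size open). For the compounds shown here, compound 4 gives 100 ug/mL, the first readable number in this small set, which shows that this place can carry a six-membered aromatic ring and that cytotoxicity can be given a number there. The number does not say how much tolerance, if any, the change costs, since it falls right at the level of the limit that the other compounds report: the limit of > 100 ug/mL in this assay, at which 3 of the 4 values shown sit.

Going by these compounds, how far compound 3 really lies from compound 4 stays open, and so does whether phenyl lowers the tolerated amount at all or the two compounds would turn out alike if compound 3 could be read as a number. Also open, on these data alone, is what this same place does when it carries something other than a plain phenyl, such as an amine, a carboxylic acid or a longer chain like butyl, and whether any of these would move the number clearly away from the level seen so far.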